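A few compounds are considered here, and "the series" means these few. Any claim that something is new, unique, unknown or untested is made for them only; others in the source may bear on it.

Compound 1, `CC(C)(C)OC(=O)/C(C#N)=C/c1ccc(O)c(O)c1`, is measured in a functional assay on the whole organism (strain CD1) for inhibition, with Mus musculus as the target, with stated times of 15 min and 20 min, at a dose of 10 mg/kg by the subcutaneous route (on this read-out higher numbers stand for more inhibition at the one dose given (going by the name of the read-out) and lower numbers for less inhibition), where compound 1 gives 43.4%. Compound 2, `CC(C)CCOC(=O)/C(C#N)=C/c1ccc(O)c(O)c1`, differs from compound 1 by a single change, (isopentyl in place of tert-butyl on an oxygen next to a carbonyl group), and in this assay compound 2 gives 27.2%. That change made a step of a number 16.2 percentage points lower from compound 1 to compound 2 (beyond the scatter). Compound 3, `CC(C)(C)OC(=O)/C(C#N)=C/c1ccoc1`, carries a different core; the difference between the two cores is not broken down here. In this assay compound 3 gives 81.8%, the highest of the three numbers, with compound 1 nearest and compound 2 furthest, both beyond the scatter. Compound 4, `CC(C)CCOC(=O)/C(C#N)=C/c1ccoc1`, has not yet been measured. It stands to compound 3 exactly as compound 2 stands to compound 1: the change is isopentyl in place of tert-butyl on an oxygen next to a carbonyl group, at the same place, so it is the same change seen a second time. The step from compound 3 to compound 4 is expected to be a number 15.8 percentage points lower from compound 3 to compound 4 (beyond the scatter), a size resting on the earlier step of a number 16.2 percentage points lower from compound 1 to compound 2 (beyond the scatter), the only other occurrence of this change. On that basis compound 4 is estimated to give 66% in this assay, most likely between 50% and 80%.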

Compound 4, a percentage reported as inhibition, in the whole organism at one dose (the size of the read-out at that dose, not a potency): 82.2%
Compound 4: the middle estimate sits 16.2 percentage points below what was measured; measured number above the stated range.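

In this assay the change to isopentyl in place of tert-butyl on an oxygen next to a carbonyl group gives a number 0.4 percentage points higher from compound 3 to compound 4 (within the scatter) and so leaves the read-out unmoved on the core of compound 3. The change therefore did not carry over from the core of compound 1 to the core of compound 3 with the same size: the same change on two cores in this assay, a number 16.2 percentage points lower (beyond the scatter) from compound 1 to compound 2 and a number 0.4 percentage points higher (within the scatter) from compound 3 to compound 4, 16.6 percentage points apart, beyond the scatter of two such steps. Within the data shown here, with only two pairs, this shows that a step seen on one core cannot simply be transferred to the other, but it does not show which part of either core accounts for the gap, or what the change would do on a third core.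

The compounds shown carry only tert-butyl and isopentyl on that oxygen, so it remains open how a shorter chain such as ethyl, a longer chain such as octyl, or a benzyl group would read on either core. On these data alone, it is also open whether an amide or a carboxylic acid in place of these esters would follow the core of compound 1 or the core of compound 3.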